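The compounds below may be only part of what the source reports. "The series", "measured", "known", "first", "only" and "open" are said of these compounds alone.

Measured in a functional assay on K562 cells (Homo sapiens) for inhibition, read by sulforhodamine B assay, with a stated time of 48 h, tested at 10 uM; a higher number here means a weaker effect of the compound at the concentration tested, a lower number a stronger effect:

compound 1 `COc1cc(Cl)cc(-c2nn(-c3cccc(NC(=O)Nc4ccc(Cl)c(C(F)(F)F)c4)c3)cc2-c2ccncc2)c1` gives 8.93%
compound 2 `COc1cc(Cl)cc(-c2nn(-c3cccc(NC(=O)Nc4cc(C(F)(F)F)cc(C(F)(F)F)c4)c3)cc2-c2ccncc2)c1` gives 6.4%
compound 3 `COc1cc(Cl)cc(-c2nn(-c3cccc(NC(=O)Nc4ccc(Cl)c(Cl)c4)c3)cc2-c2ccncc2)c1` gives 10%

All three numbers lie close together at the low end of the read-out, which here means a strong effect at the concentration tested. Compound 3 has the highest of the three numbers; its nearest neighbour is compound 1, with a number 1.1 percentage points higher from compound 1 to compound 3 (within the scatter), and compound 2 stands furthest, its number also within the scatter of compound 3. Going by the values given here, no compound can be called stronger or weaker than another on these figures.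

Compound 4 `COc1cc(Cl)cc(-c2nn(-c3cccc(NC(=O)Nc4cccc(C(F)(F)F)c4)c3)cc2-c2ccncc2)c1` is not yet measured. Against compound 3 the change is 3-(trifluoromethyl)phenyl in place of 3,4-dichlorophenyl on an amide-type nitrogen. Among the compounds with values here, the one measured step that bears on it is the exchange of a chloro for a trifluoromethyl on an aromatic carbon of the same phenyl, a number 1.1 percentage points higher from compound 1 to compound 3 (within the scatter), which stayed within the scatter; compound 2, with two trifluoromethyl groups on that phenyl, also lies within the scatter of compound 1 and compound 3. Nothing measured shows what removing one substituent from this phenyl does, so the expectation rests on the substituent swaps alone.

Compound 4 is therefore expected to show no change at the digits printed from compound 3 to compound 4 (within the scatter), nothing beyond the scatter. The estimate for compound 4 in this assay is 10%, expected between 3% and 20%.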

Compound 4, a percentage reported as activity, at one concentration (the size of the read-out at that concentration, not a potency): 7.61%
For compound 4 the middle estimate is 2.4 percentage points above the measured one; measured number inside the range.
By their numbers in this assay, from the lowest: compounds 2, 4, 1 and 3 (each within the scatter of the next).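

In this assay, going by these compounds alone, the earlier compounds left open what happens when a substituent is removed from the phenyl on the amide-type nitrogen, and this can now be read: hydrogen in place of chloro gives a number 1.3 percentage points lower from compound 1 to compound 4 (within the scatter), and hydrogen in place of trifluoromethyl gives a number 1.2 percentage points higher from compound 2 to compound 4 (within the scatter). The full exchange of 3,4-dichlorophenyl for 3-(trifluoromethyl)phenyl gives a number 2.4 percentage points lower from compound 3 to compound 4 (within the scatter), so across these four compounds a phenyl with a single trifluoromethyl group cannot be told apart from the phenyls with two substituents. Nothing available explains this flat picture at the position.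

Still open, on these data alone, is whether a phenyl with no substituent, or a phenyl carrying a methoxy group, an amine or a carboxylic acid, would stay at this low end of the read-out or move beyond the scatter. As far as these compounds go, with only one tested concentration and all four numbers close together, it also remains open whether these compounds would separate at lower concentrations.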